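Swapping the Carbamate Cap for a Bromobenzoyl Group

The compounds below may be only part of what the source reports. "The series", "measured", "known", "first", "only" and "open" are said of these compounds alone.

Compound 3 `O=C(CCCCC[C@H](NC(=O)OCc1ccccc1)C(=O)Nc1ccc(-c2ccccc2)cc1)NO` gives 330 nM in a functional assay on MM96L cells (Homo sapiens) for antiproliferative activity; a lower number here means a stronger inhibitor, a higher number a weaker inhibitor. That is the lowest of the three numbers recorded: compound 1 `O=C(CCCCC[C@H](NC(=O)OCc1ccccc1)C(=O)NCc1ccccc1)NO` gives 1520 nM and compound 2 `CN(C)c1ccc(NC(=O)[C@H](CCCCCC(=O)NO)NC(=O)OCc2ccccc2)cc1` gives 610 nM, with a 4.6-fold lower number from compound 1 to compound 3 (0.66 log units; beyond the scatter) and a 2.5-fold lower number from compound 1 to compound 2 (0.40 log units; beyond the scatter), while a 1.8-fold lower number from compound 2 to compound 3 (0.27 log units; within the scatter), so compound 3 and compound 2 cannot be ranked against each other. Compound 4 `O=C(CCCCC[C@H](NC(=O)c1ccc(Br)cc1)C(=O)Nc1ccc(-c2ccccc2)cc1)NO` differs from compound 3 at the other end of the molecule: 4-bromophenyl in place of benzyloxy on a carbonyl carbon. Every measured step altered only the group on the amide-type nitrogen, so none bears on this change at the carbonyl carbon. Without such a guide, the step is expected to stay within the scatter, a 1.1-fold lower number from compound 3 to compound 4 (0.04 log units; within the scatter). In this assay compound 4 is therefore estimated at 300 nM, with a range from 100 nM to 900 nM.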

Compound 4, half-maximal inhibitory concentration: 70 nM
For compound 4 the middle estimate is 4.3-fold (0.63 log units) above the measured one; measured number outside the range, below it.
By their numbers in this assay, from the lowest: compound 4; then compounds 3 and 2 (each within the scatter of the next); then compound 1.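

In this assay, 4-bromophenyl in place of benzyloxy on a carbonyl carbon gives a 4.7-fold lower number from compound 3 to compound 4 (0.67 log units; beyond the scatter), so this end of the molecule, unchanged among compounds 1 to 3, also shifts the number beyond the scatter. Nothing shown explains this drop.

The compounds shown do not separate the role of the bromine from that of the lost benzyloxy group, a question that an unsubstituted phenyl or a 4-chlorophenyl at this place could address. On these data alone, whether the gain carries over to compound 2, with its 4-(dimethylamino)phenyl group, also stays open.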